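The source may hold more compounds than are shown below. What is called first, only, known or untested is meant among the compounds shown, and "the series" means these compounds.

Within the data shown here, in a functional assay on MIA PaCa-2 cells (Homo sapiens) for antiproliferative activity, read by MTT assay, with a stated time of 3 days (a lower number here means a stronger inhibitor, a higher number a weaker inhibitor), compound 2, with the structure `CCCCCC#Cc1cn(C/C=C/CN2C(=O)c3ccccc3C2=O)c(=O)[nH]c1=O`, gives 60000 nM, the only plain number in this small set. Compound 1, with the structure `CCCCCCCCC#Cc1cn(C/C=C/CN2C(=O)c3ccccc3C2=O)c(=O)[nH]c1=O`, gives > 100000 nM, which is a limit of the assay rather than a measured number. Among the measured compounds shown here, the one measured step, an at least 1.6-fold lower number from compound 1 to compound 2 (0.22 log units; that floor lies within the scatter), trims the long chain and is anchored to the limit of > 100000 nM in this assay, at which 1 of the 2 values shown sits. Compound 3, with the structure `CCCCc1ccc(C#Cc2cn(C/C=C/CN3C(=O)c4ccccc4C3=O)c(=O)[nH]c2=O)cc1`, differs from compound 2 by 4-butylphenyl in place of pentyl on a triple-bonded carbon. For the measured compounds named here, no measured step in this set brings an aromatic ring onto the triple-bonded carbon, so the measured step between compound 1 and compound 2, a chain change that stays within the usual scatter, is only a loose guide and gives no direction for this change. Compound 3 is therefore expected to sit near 30000 nM, in a wide range from 5000 nM to 100000 nM. For compound 3 this estimate corresponds to an expected step of a 2.0-fold lower number from compound 2 to compound 3 (0.30 log units; within the scatter).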

Compound 3, half-maximal inhibitory concentration: 79000 nM
Compound 3: the middle estimate sits 2.6-fold (0.42 log units) below what was measured; measured number inside the range.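

On the triple-bonded carbon, an aromatic ring can now be set against a plain chain, and in this assay the change from pentyl to 4-butylphenyl gives a 1.3-fold higher number from compound 2 to compound 3 (0.12 log units; within the scatter), so the added ring brings no shift that stands clear of the scatter. Against the octyl chain, the reading rests on a limit of the assay and not on a number, and it gives an at least 1.2-fold lower number from compound 1 to compound 3 (0.10 log units; that floor lies within the scatter). All three compounds lie at the high end of this scale, and none stands clear of the others: the limit of > 100000 nM in this assay, at which 1 of the 3 values shown sits.

As far as these compounds go, it remains open whether a chain carrying an amine or a carboxylic acid on the triple-bonded carbon would move the number beyond the scatter. From the compounds shown here alone, a much shorter chain, such as methyl, or a plain phenyl ring without the butyl group, is equally open.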